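Sulfone series: growth inhibition notes toward compound 3

This account rests on a few compounds, and the source may have more. Where it says the series, first, only, none or still open, it means among the compounds named here.

Two measured compounds define the present level of the series. Among the measured compounds shown here, compound 1 `Cc1cc(C)cc(/C=C(/Sc2ccc(Br)cc2)C(=O)c2ccc(Cl)cc2)c1` is the first. In a functional assay on DU-145 cells (Homo sapiens) for inhibition, read by trypan blue exclusion, with a stated time of 96 h (on this read-out lower numbers stand for stronger inhibition of growth and higher numbers for weaker inhibition of growth), compound 1 gives 10000 nM. Compound 2 `O=C(/C(=C\c1ccc(O)cc1)S(=O)(=O)Cc1ccc(F)cc1)c1ccc(Br)cc1` carries a 4-hydroxyphenyl on a double-bonded chain carbon bound to a double-bonded chain carbon. In this assay compound 2 gives 10000 nM, level with compound 1 at the digits recorded; the two values lie within the scatter of each other, so no order can be read between them and neither can be called the more active.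

Compound 3 `O=C(/C(=C\c1cc([N+](=O)[O-])ccc1F)S(=O)(=O)Cc1ccc(F)cc1)c1ccc(Br)cc1` has not yet been measured. It differs from compound 2 by 2-fluoro-5-nitrophenyl in place of 4-hydroxyphenyl on a double-bonded chain carbon bound to a double-bonded chain carbon. For the measured compounds named here, no step between measured compounds is available to calibrate a change of this kind, and the two values in hand do not separate from each other, so the expectation can rest only on their common level. The step of no change at the digits printed from compound 2 to compound 3 (within the scatter) is expected to remain within the scatter, with no direction favoured. Compound 3 is accordingly expected to give about 10000 nM, with a range from 3000 nM to 20000 nM.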

Compound 3, concentration for 50% growth inhibition: > 100000 nM
Compound 3: no number, only a limit; the forecaster's own chance of this, stated with the estimate: 50%; middle value at least 10-fold (1.00 log units) from the limit.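

In this assay compound 3 gives > 100000 nM, which is a limit of the assay and not a number. Among the compounds shown here, the position on a double-bonded chain carbon bound to a double-bonded chain carbon is therefore not indifferent to its aryl group: 2-fluoro-5-nitrophenyl in place of 4-hydroxyphenyl gives an at least 10-fold higher number from compound 2 to compound 3 (1.00 log units; beyond the scatter), the first step that can be read and one that marks a loss of growth inhibition. This size is only a lower bound, and how far the loss extends past it cannot be read: the limit of > 100000 nM in this assay, at which 1 of the 3 values shown sits.

The compounds shown leave open which part of the exchange carries the loss, whether the fluoro or the nitro of 2-fluoro-5-nitrophenyl or the absence of the hydroxyl of 4-hydroxyphenyl, since all three change in a single step. They also leave open whether growth inhibition at this position can rise beyond the level of compound 2, and what an amine or a carboxylic acid in place of that hydroxyl on the same ring would give.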